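This account rests on a few compounds, and the source may have more. Where it says the series, first, only, none or still open, it means among the compounds named here.

Compound 1 `N#Cc1ccc(NC(=O)c2cc(Cc3ccccc3)ccc2O)cc1` gives 1740 nM in a functional assay on HL-60 cells (Homo sapiens) for cytotoxicity, read by luminescence and CellTiter-Glo, with a stated time of 3 days; a higher number here means a weaker inhibitor, a lower number a stronger inhibitor. Compound 2 `COc1ccc(C(=O)Nc2ccc(C#N)cc2)c(O)c1` gives 5470 nM in this assay.

Compound 1 stands lowest of the two numbers in this assay; compound 2 is the nearest, and its gap to compound 1 lies beyond the scatter. Compound 3 `N#Cc1ccc(NC(=O)c2cc(Cl)ccc2O)cc1` differs from compound 1 by chloro in place of benzyl on an aromatic carbon. Among the measured compounds shown here, no measured step of this kind is available to anchor the change. It is expected that the step of a 2.6-fold higher number from compound 1 to compound 3 (0.41 log units; beyond the scatter) runs toward a higher number, beyond the scatter. Compound 3 is therefore estimated at 4500 nM in this assay, within a range of 1500 nM to 14000 nM.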

Compound 3, half-maximal inhibitory concentration: 700 nM
Compound 3: the middle estimate sits 6.4-fold (0.81 log units) above what was measured; measured number below the stated range.
By their numbers in this assay, from the lowest: compound 3; then compound 1; then compound 2.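

On the aromatic carbon para to a hydroxy group, the benzyl and its ring are not required for activity in this assay: chloro in place of benzyl gives a 2.5-fold lower number from compound 1 to compound 3 (0.40 log units; beyond the scatter). A single chlorine atom thus suffices here where seven carbons stood, and the smaller group gives the lower number. No measurement shown accounts for this change.

This single step does not show how other groups behave at this position. From the compounds shown here alone, whether a bromo, an amine or a carboxylic acid on this carbon would fall above or below compound 3 remains open.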